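The compounds below may be only part of what the source reports. "The series", "measured", "known", "first", "only" and "open" are said of these compounds alone.

Compound 1 `Cc1noc(C)c1-c1cccc(Oc2ccc(C#N)c(C(F)(F)F)c2)c1`: "not determined" (no result reported)
Compound 2 `CCN(c1ccc(C#N)c(Cl)c1)c1cc(-n2cnc3ccccc32)ccc1C`: 8160 nM
Compound 3 `N#Cc1ccc(N2CCCc3c(-c4ccncc4)cccc32)cc1C(F)(F)F`: 28700 nM

In a functional assay on PC-3 cells (Homo sapiens) for antiproliferative activity, read by CCK-8 assay, with a stated time of 6 days (a higher number here means a weaker inhibitor, a lower number a stronger inhibitor), compound 1 has no reported number, which leaves two values to compare. Compound 2 stands lowest at 8160 nM, and compound 3 gives a higher number, 28700 nM, a gap beyond the scatter. Compound 4 `CCN(c1ccc(C#N)c(Cl)c1)c1cc(-c2cccs2)ccc1C` changes compound 2 in one place: thiophen-2-yl in place of 1H-benzimidazol-1-yl on an aromatic carbon. Here thiophen-2-yl takes the place of 1H-benzimidazol-1-yl on an aromatic carbon. Within the data shown here, no measured pair shows what this swap does, so this assay is expected to show no step beyond the scatter, with neither direction favoured. The estimated change is a 1.2-fold higher number from compound 2 to compound 4 (0.09 log units; within the scatter). The expected value for compound 4 is 10000 nM, with an estimated range of 3500 nM to 30000 nM.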

Compound 4, half-maximal inhibitory concentration: > 30000 nM
Compound 4 gave a limit, no number; the forecaster's own chance of this, stated with the estimate: 15%; at least 3.0-fold (0.47 log units) between middle value and limit.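

In this assay, this aromatic carbon, para to a methyl group, does not tolerate every aromatic ring: thiophen-2-yl in place of 1H-benzimidazol-1-yl gives an at least 3.6-fold higher number from compound 2 to compound 4 (0.56 log units; beyond the scatter). Compound 4 reads as a limit of the assay and not as a number: the limit of > 30000 nM in this assay, at which 1 of the 4 values shown sits. Among these compounds, the full size of this loss therefore stays unknown, and the earlier compounds, which differ in more than one place, could not show it.

From the compounds shown here alone, what stays open is whether the activity of compound 2 depends on the fused six-membered ring or on the ring nitrogens. An imidazol-1-yl group at this carbon would help separate the two.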